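This account rests on a few compounds, and the source may have more. Where it says the series, first, only, none or still open, it means among the compounds named here.

In an assay on microsomes for inhibition of acyl-CoA:cholesterol acyltransferase (Oryctolagus cuniculus) (on this read-out lower numbers stand for stronger inhibition and higher numbers for weaker inhibition), compound 1 `Cc1ccc(C2(CNC(=O)Nc3c(C(C)C)cccc3C(C)C)CCCC2)cc1` gives 25 nM, and compound 2 `CC(C)c1cccc(C(C)C)c1NC(=O)NCC1(c2ccc(C(C)(C)C)cc2)CCCC1` gives 63 nM. Within the data shown here, compound 2 thus stands at the highest of the two numbers so far, its nearest neighbour being compound 1 with a lower number. Among the measured compounds shown here, the one measured step, a 2.5-fold higher number from compound 1 to compound 2 (0.40 log units; beyond the scatter), is the only guide to what happens at the place where compound 3 differs. Compound 3 `CC(C)c1cccc(C(C)C)c1NC(=O)NCC1(c2ccc(CO)cc2)CCCC1` differs from compound 2 in one place: hydroxymethyl in place of tert-butyl on an aromatic carbon. Hydroxymethyl is neither of the two groups already tried at that aromatic carbon, so the step from compound 1 to compound 2 shows only that exchanging the group there moves the number modestly. A step of similar size is therefore expected, more likely back toward the number of compound 1 than further away, with wide uncertainty. Compound 3 is accordingly estimated at 40 nM, between 13 nM and 130 nM, meaning an expected step of a 1.6-fold lower number from compound 2 to compound 3 (0.20 log units; within the scatter).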

Compound 3, half-maximal inhibitory concentration: 26 nM
Compound 3: middle estimate off by 1.5-fold (0.19 log units), on the high side, within the range that was stated.
By their numbers in this assay, from the lowest: compounds 1 and 3 (each within the scatter of the next); then compound 2.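

In this assay, hydroxymethyl in place of tert-butyl gives a 2.4-fold lower number from compound 2 to compound 3 (0.38 log units; beyond the scatter), so the higher number of the tert-butyl compound does not hold for every other group at this aromatic carbon. Hydroxy in place of a hydrogen on the carbon attached to the ring gives a 1.0-fold higher number from compound 1 to compound 3 (0.02 log units; within the scatter), which means the methyl and hydroxymethyl compounds cannot be told apart here. Among the three groups shown, tert-butyl alone stands apart, and a group with one hydrogen-bond donor and one hydrogen-bond acceptor is tolerated at this position.

From the compounds shown here alone, it remains open how an amine, a carboxylic acid or a longer chain such as hydroxyethyl would behave at this carbon, and whether group size or the hydroxy matters more in the step away from tert-butyl. Nothing available here explains why tert-butyl differs from the other two groups.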